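A 2-phenylethenyl swap at the edge of measurement

The compounds below may be only part of what the source reports. "The series", "measured", "known", "first", "only" and "open" are said of these compounds alone.

In a functional assay on SK-MEL-28 cells (Homo sapiens) for inhibition, read by MTT assay, with a stated time of 48 h (on this read-out higher numbers stand for weaker inhibition and lower numbers for stronger inhibition), compound 1 (`CS(=O)(=O)c1ccc(-c2nc3ccccn3c2Sc2ccccc2)cc1`) gives 61900 nM. Compound 2 (`Cc1ccc(-c2nc3ccccn3c2Sc2ccccc2)cc1`) gives > 100000 nM, which is a limit of the assay and not a number. Compound 3 (`c1ccc(Sc2c(-c3cccc4ccccc34)nc3ccccn23)cc1`) gives > 100000 nM, again only a limit. Compound 2 therefore has no number of its own and stands at the limit of > 100000 nM in this assay, at which 2 of the 3 values shown sit. For the measured compounds named here, the one measured step is an at least 1.6-fold higher number from compound 1 to compound 2 (0.20 log units; that floor lies within the scatter).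

Compound 4 (`C(=C/c1nc2ccccn2c1Sc1ccccc1)\c1ccccc1`) changes compound 2 at a single place: 2-phenylethenyl in place of 4-methylphenyl on an aromatic carbon. Here 2-phenylethenyl replaces 4-methylphenyl, and each group holds one six-membered aromatic ring of carbon only. Going by the values given here, no measured step makes this exchange, so the step from compound 1 to compound 2 is only a loose guide, and it stays within the scatter at its floor. No change beyond the scatter is expected in this assay. The expected step is an at least 1.2-fold lower number from compound 2 to compound 4 (0.09 log units; that floor lies within the scatter). Compound 4 is estimated at 80000 nM, with an expected range from 30000 nM to 200000 nM. It may also read out only as a limit.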

Compound 4, half-maximal inhibitory concentration: 65400 nM
The estimate for compound 4 lay 1.2-fold (0.09 log units) above the measured number; measured number inside the range.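

Compound 4 is the first compound shown without a methylsulfonyl group that returns a number in this assay, so a value that can be read at this position does not depend on that group. As far as these compounds go, the exchange of 4-methylphenyl for 2-phenylethenyl amounts to an at least 1.5-fold lower number from compound 2 to compound 4 (0.18 log units; that floor lies within the scatter), and that figure is only a floor, so the true size of the step remains unknown. Compound 2 itself offers only a limit of the assay, not a number: the limit of > 100000 nM in this assay, at which 2 of the 4 values shown sit.

From the compounds shown here alone, whether the double bond of 2-phenylethenyl matters at all stays open, as a saturated 2-phenylethyl chain at the same place would be needed to tell. Also open, going by these compounds, is how an amine or a carboxylic acid on the aromatic ring of the 2-phenylethenyl group would read out in this assay.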